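Swapping the sulfonyl aryl group on a quinolone core

A few compounds are considered here, and "the series" means these few. Any claim that something is new, unique, unknown or untested is made for them only; others in the source may bear on it.

The study works on a shared core, seen in compound 1 (`COc1ccc(-c2cc(=O)c3c(OC)cc(OC)cc3[nH]2)cc1`), read out in a functional assay on SEM cells (Homo sapiens) for antiproliferative activity, with a stated time of 72 h; a lower number here means that less compound is needed, a higher number that more compound is needed for the effect. For compound 1 the result is only a limit of the assay, > 31100 nM. Compound 2 (`COc1ccc(-c2cc(=O)c3c(OC)cc(OC)cc3n2S(=O)(=O)c2ccc(C)c([N+](=O)[O-])c2)cc1`) carries a sulfonyl group on the ring nitrogen of that core; in this assay compound 2 gives "not determined" (no result reported), so it stands with no number of its own. The only anchor is the limit of > 31100 nM in this assay, at which 1 of the 2 values shown sits. Compound 3 (`COc1ccc(-c2cc(=O)c3c(OC)cc(OC)cc3n2S(=O)(=O)c2ccc(C#N)cc2)cc1`) differs from compound 2 in one place: 4-cyanophenyl in place of 4-methyl-3-nitrophenyl on a sulfonyl sulfur. For the measured compounds named here, no measured step exists for this change, so its size and direction cannot be read from the data, and no effect beyond the usual scatter is assumed. For compound 3 the estimated half-maximal effective concentration in this assay is 15000 nM, expected to fall between 2000 nM and 40000 nM.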

Compound 3, half-maximal effective concentration: 1300 nM
Compound 3: the middle estimate sits 12-fold (1.06 log units) above what was measured; measured number below the stated range.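

In this assay, putting (4-cyanophenyl)sulfonyl in place of hydrogen on the aromatic nitrogen gives an at least 23-fold lower number from compound 1 to compound 3 (1.37 log units; beyond the scatter). For the compounds shown here, compound 2 carries a sulfonyl aryl group at this same place but has no result, so compound 3 gives the first evidence that such a group on this nitrogen can go with a measurable effect on these cells. The value for compound 1 is a limit and not a number, so the true size of this step stays unknown: the limit of > 31100 nM in this assay, at which 1 of the 3 values shown sits.

The step from compound 2 to compound 3 cannot be read, so the data do not say how 4-cyanophenyl compares with 4-methyl-3-nitrophenyl. Also open, going by these compounds, is how a plain phenyl on the sulfonyl sulfur, or an aryl ring bearing an amine or a carboxylic acid, would behave here.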